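Aryl ether in place of carbamate on the side chain

The source may hold more compounds than are shown below. What is called first, only, known or untested is meant among the compounds shown, and "the series" means these compounds.

Measured compounds:
compound 1 `COc1nc(C)c(Nc2nc(Cl)cn([C@H](COC(=O)c3cccnc3)C3CC3)c2=O)cc1C` with 5.2 nM
compound 2 `COc1nc(C)c(Nc2nc(Cl)cn([C@H](COC(=O)Nc3ccc(Cl)cc3Cl)C3CC3)c2=O)cc1C` with 1.7 nM
compound 3 `CCNC(=O)OC[C@H](C1CC1)n1cc(Cl)nc(Nc2cc(C)c(OC)nc2C)c1=O` with 14 nM

In an assay on frontal cortex for displacement of a labelled ligand from corticotropin-releasing factor receptor 1 (Rattus norvegicus), with a stated time of 2 h (a lower number here means a stronger inhibitor, a higher number a weaker inhibitor), compound 3 gives the highest of the three numbers. Its nearest neighbour is compound 1, reached by a 2.7-fold higher number from compound 1 to compound 3 (0.43 log units; beyond the scatter), and the widest gap is to compound 2, reached by an 8.2-fold higher number from compound 2 to compound 3 (0.92 log units; beyond the scatter). Compound 4 `COc1nc(C)c(Nc2nc(Cl)cn([C@H](COc3cc(Br)ccn3)C3CC3)c2=O)cc1C` differs from compound 3 in one place: 4-bromopyridin-2-yl in place of ethylcarbamoyl on an oxygen on a saturated carbon. Going by the values given here, no measured pair shows exactly this exchange of a carbamate for an aryl ether. Among the compounds with values here, the steps that bear on it are a 2.7-fold higher number from compound 1 to compound 3 (0.43 log units; beyond the scatter) and an 8.2-fold higher number from compound 2 to compound 3 (0.92 log units; beyond the scatter), both of which show that the ethylcarbamoyl end of compound 3 gives a weaker result than either the pyridin-3-yl carbonyl of compound 1 or the (2,4-dichlorophenyl)amino carbonyl of compound 2. Since compound 4 brings in a six-membered aromatic ring with one hetero atom where compound 3 carries only a short chain, the expected direction is toward a lower number, of a size near a 2.8-fold lower number from compound 3 to compound 4 (0.45 log units; beyond the scatter). Compound 4 is therefore estimated at 5 nM, in the range 1.5 nM to 20 nM.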

Compound 4, half-maximal inhibitory concentration: 1.5 nM
Estimate against measurement, compound 4: 3.3-fold (0.52 log units) above; measured number inside the range.
By their numbers in this assay, from the lowest: compounds 4 and 2 (each within the scatter of the next); then compound 1; then compound 3.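

In this assay, 4-bromopyridin-2-yl on this oxygen gives a 9.3-fold lower number from compound 3 to compound 4 (0.97 log units; beyond the scatter), so a low number at this position does not depend on a carbonyl or on the amide hydrogen of the carbamate. The aryl ether also improves on the ester, with a 3.5-fold lower number from compound 1 to compound 4 (0.54 log units; beyond the scatter), while a 1.1-fold lower number from compound 2 to compound 4 (0.05 log units; within the scatter) lies within the scatter, so compound 4 and compound 2 cannot be ordered even though compound 4 has no carbonyl on this oxygen. The data give no measurement that would explain these steps.

This single exchange cannot separate the loss of the carbamate from the gain of the ring or the bromine. Going by these compounds, what a plain pyridin-2-yl, a phenyl or a 4-methoxypyridin-2-yl would give on this oxygen remains open, as does the effect of an amine in place of the oxygen.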